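Swapping the oxazole for methylsulfanyl on the phenylpiperazine ring

A few compounds are considered here, and "the series" means these few. Any claim that something is new, unique, unknown or untested is made for them only; others in the source may bear on it.

Of the compounds shown here, three sharing one core have been measured in a functional assay on aorta for antagonist activity at Alpha-1D adrenergic receptor (Rattus norvegicus); on this read-out higher numbers stand for weaker binding and lower numbers for tighter binding. Compound 1 `CN(C)C(=O)c1cccnc1NCCCN1CCN(c2ccccc2)CC1` carries hydrogen at the position of interest and gives 15.9 nM. Compound 2 `CN(C)C(=O)c1cccnc1NCCCN1CCN(c2ccccc2C#N)CC1` carries a cyano group there and gives 10 nM. Compound 3 `CN(C)C(=O)c1cccnc1NCCCN1CCN(c2ccccc2-c2ncco2)CC1` carries a 1,3-oxazol-2-yl group and gives 25.1 nM, the highest of the three numbers; its step to compound 1 is within the scatter, while the step from compound 2 is a 2.5-fold higher number from compound 2 to compound 3 (0.40 log units; beyond the scatter).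

Compound 4 `CSc1ccccc1N1CCN(CCCNc2ncccc2C(=O)N(C)C)CC1` differs from compound 3 in one place: methylsulfanyl in place of 1,3-oxazol-2-yl on an aromatic carbon. Among the compounds with values here, no measured compound carries methylsulfanyl, so the expectation rests on what happened when the oxazole was exchanged for something smaller: a 1.6-fold higher number from compound 1 to compound 3 (0.20 log units; within the scatter) read backwards is a small lowering within the scatter, and a 2.5-fold higher number from compound 2 to compound 3 (0.40 log units; beyond the scatter) read backwards is a modest lowering. A step of similar modest size toward a lower number is therefore expected in this assay, a 1.9-fold lower number from compound 3 to compound 4 (0.29 log units; within the scatter). Compound 4 is estimated at 13 nM, with a range from 5 nM to 32 nM.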

Compound 4, dissociation constant: 31.6 nM
Compound 4: the middle estimate sits 2.4-fold (0.39 log units) below what was measured, and the stated range covers the measured number.
By their numbers in this assay, from the lowest: compounds 2, 1, 3 and 4 (each within the scatter of the next, the first and the last beyond it).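

In this assay, replacing the ring-bearing 1,3-oxazol-2-yl with the smaller, ring-free methylsulfanyl gives a 1.3-fold higher number from compound 3 to compound 4 (0.10 log units; within the scatter), so these two groups cannot be told apart on this read-out. Methylsulfanyl also cannot be separated from plain hydrogen at this aromatic carbon, with a 2.0-fold higher number from compound 1 to compound 4 (0.30 log units; within the scatter). Cyano does separate from it, with a 3.2-fold higher number from compound 2 to compound 4 (0.50 log units; beyond the scatter), so compound 2 now stands apart from both the oxazole and the methylsulfanyl compounds, although it remains within the scatter of the hydrogen compound.

Nothing available explains why the numbers fall this way. As far as these compounds go, it remains open whether a methoxy group, an amine or a carboxylic acid at this same place would give a number that stands clearly apart from those of the hydrogen and cyano compounds.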